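Amino in place of hydrogen on the core of compound 3

The compounds below may be only part of what the source reports. "The series", "measured", "known", "first", "only" and "open" are said of these compounds alone.

Measured compounds:
Compound 1, `ClCc1ccc(Cn2cnc3c(Cl)ncnc32)cc1`, in a functional assay on NCI-H226 cells (Homo sapiens) for cytotoxicity, read by sulforhodamine B assay, with a stated time of 48 h (on this read-out lower numbers stand for stronger inhibition of growth and higher numbers for weaker inhibition of growth), gives 7410 nM.
Compound 2, `ClCc1ccccc1Cn1cnc2c(Cl)nc(Cl)nc21`, gives 3380 nM.
Compound 3, `ClCc1ccccc1Cn1cnc2c(Cl)ncnc21`, gives 12600 nM.

Compound 3 holds the highest of the three numbers. Its nearest neighbour is compound 1, whose number lies within the scatter of that of compound 3, so no order between the two can be read. Among the compounds with values here, compound 2 stands further off: the single step of a 3.7-fold higher number from compound 2 to compound 3 (0.57 log units; beyond the scatter) is the only measured change at this position, and it shows that removing chloro there weakens growth inhibition by a modest amount.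

Compound 4, `Nc1nc(Cl)c2ncn(Cc3ccccc3CCl)c2n1`, differs from compound 3 by amino in place of hydrogen on an aromatic carbon. Within the data shown here, no measured compound carries an amino group at this position, so the one related step, hydrogen for chloro, bears on it only indirectly: it shows the position is sensitive to substitution, but not in which direction an amino group would act. Compound 4 is therefore expected to show a small step, a 1.6-fold lower number from compound 3 to compound 4 (0.20 log units; within the scatter), toward stronger growth inhibition. The estimate for compound 4 is 8000 nM, with a range from 2500 nM to 25000 nM.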

Compound 4, concentration for total growth inhibition: 10000 nM
Compound 4: middle estimate off by 1.3-fold (0.10 log units), on the low side; the measured number falls inside the stated range.
By their numbers in this assay, from the lowest: compound 2; then compounds 1, 4 and 3 (each within the scatter of the next).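

In this assay, amino on the aromatic carbon between two ring nitrogen atoms gives a 1.3-fold lower number from compound 3 to compound 4 (0.10 log units; within the scatter), so compound 4 cannot be told apart from compound 3. Chloro at the same place does stand apart from amino, with a 3.0-fold higher number from compound 2 to compound 4 (0.47 log units; beyond the scatter), so among these three compounds the position separates chloro from both hydrogen and amino, rather than any substituent from hydrogen. Nothing available here accounts for this difference.

On these data alone, it remains open whether bromo, methoxy or methylamino at this position would give a number close to that of compound 2 or one close to those of compound 3 and compound 4. As far as these compounds go, it also remains open whether chloro and amino would separate in the same way on the core of compound 1, where the chloromethyl group sits elsewhere on the benzyl ring.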